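The source may report more compounds than this note shows. Statements on the series, on what has been measured and on what is new or still open speak of the compounds shown alone.

Compound 1, `CCCc1nc(C)c2c(C)nn(C)c(=O)n12`: in a functional assay for inhibition, with Homo sapiens as the target (a higher number here means a weaker inhibitor, a lower number a stronger inhibitor), compound 1 gives > 48000 nM, which is a limit of the assay and not a number.
Compound 2, `CCCc1nn(C)c(=O)n2c(CCC)nc(C)c12`: in this assay compound 2 gives 18000 nM.
Compound 3, `CCCc1ncc2cnnc(SC)n12`: in this assay compound 3 gives > 48000 nM, again a limit of the assay.

Within the data shown here, the one measured step, an at least 2.6-fold higher number from compound 2 to compound 1 (0.42 log units; beyond the scatter), comes from hydrogen in place of ethyl on a saturated chain carbon bound to an aromatic carbon. How the core of compound 3 differs from the core of compound 2 is not broken down here.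

Compound 4, `CSc1nncc2cnc(C)n12`, is not yet measured. It differs from compound 3 by hydrogen in place of ethyl on a saturated chain carbon bound to an aromatic carbon, the same change as between compound 2 and compound 1, at the same place. Since compound 3 already sits at the limit of > 48000 nM in this assay, at which 2 of the 3 values shown sit, and the measured step of an at least 2.6-fold higher number from compound 2 to compound 1 (0.42 log units; beyond the scatter) weakened inhibition, compound 4 is expected to remain at or beyond that limit. Compound 4 is therefore estimated at 70000 nM. For compound 4 the expected range runs from 25000 nM to 250000 nM. The step this estimate implies, a step that the limit leaves unreadable from compound 3 to compound 4, is expected to be small or unmeasurable.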

Compound 4, half-maximal inhibitory concentration: > 48000 nM
Compound 4: no number, only a limit (the forecaster's own chance of this, stated with the estimate: 85%); the middle value does not contradict the limit.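

Among these compounds, compound 3 and compound 4 both give only a limit and not a number, so no step between them can be read: the limit of > 48000 nM in this assay, at which 3 of the 4 values shown sit. The compounds shown leave open whether replacing ethyl with hydrogen changes inhibition at all on the core of compound 3.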